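Swapping a hydroxy for fluoro on the sugar of compound 3

The source may hold more compounds than are shown below. What is called first, only, known or untested is meant among the compounds shown, and "the series" means these compounds.

Compound 1 `N=C(N)NCCC[C@H](N)C(=O)NCC(=O)N[C@@H](CC(=O)O)C(=O)N[C@@H](CSCc1cn(CCO[C@@H]2O[C@H](CO)[C@H](O)[C@H](O)[C@H]2O)nn1)C(=O)O` gives 23000 nM in a functional assay on a cell-free system (Platelet, plasma, Homo sapiens) for inhibition, with a stated time of 10 min, at 37 degrees C; a higher number here means a weaker inhibitor, a lower number a stronger inhibitor. Compound 2 `N=C(N)NCCC[C@H](N)C(=O)NCC(=O)N[C@@H](CC(=O)O)C(=O)N[C@@H](CSCc1cn(CCO[C@@H]2O[C@H](CF)[C@@H](O)[C@H](O)[C@H]2O)nn1)C(=O)O` gives 66000 nM, and compound 3 `N=C(N)NCCC[C@H](N)C(=O)NCC(=O)N[C@@H](CC(=O)O)C(=O)N[C@@H](CSCc1cn(CCO[C@H]2O[C@H](CO)[C@@H](O)[C@H](O)[C@@H]2O)nn1)C(=O)O` gives 47600 nM, the second highest of the three numbers, sitting close to compound 2 and beyond the scatter from compound 1. Compound 4 `N=C(N)NCCC[C@H](N)C(=O)NCC(=O)N[C@@H](CC(=O)O)C(=O)N[C@@H](CSCc1cn(CCO[C@H]2O[C@H](CF)[C@@H](O)[C@H](O)[C@@H]2O)nn1)C(=O)O` is not yet measured; it differs from compound 3 by fluoro in place of hydroxy on a saturated chain carbon bound to a saturated ring carbon. The same change has been made once before: a 2.9-fold higher number from compound 1 to compound 2 (0.46 log units; beyond the scatter). Compound 4 also relates to compound 2 through the stereo change seen in a 2.1-fold higher number from compound 1 to compound 3 (0.32 log units; beyond the scatter). Both routes point the same way, so a modest rise in the number is expected, a 2.7-fold higher number from compound 3 to compound 4 (0.44 log units; beyond the scatter). Compound 4 is therefore estimated at 130000 nM, within a range of 60000 nM to 280000 nM.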

Compound 4, half-maximal inhibitory concentration: 23500 nM
The estimate for compound 4 lay 5.5-fold (0.74 log units) above the measured number, outside the stated range (below it).
By their numbers in this assay, from the lowest: compounds 1 and 4 (each within the scatter of the next); then compounds 3 and 2 (each within the scatter of the next).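

In this assay, fluoro in place of hydroxy on this saturated chain carbon does not act alike on the two sugar forms: a 2.9-fold higher number from compound 1 to compound 2 (0.46 log units; beyond the scatter), whereas a 2.0-fold lower number from compound 3 to compound 4 (0.31 log units; beyond the scatter). The stereo change also runs the opposite way with fluoromethyl, a 2.8-fold lower number from compound 2 to compound 4 (0.45 log units; beyond the scatter), against a 2.1-fold higher number from compound 1 to compound 3 (0.32 log units; beyond the scatter) with hydroxymethyl, although this comparison carries a caveat: the fact that one of compounds 2 and 4 is drawn with a defined configuration and the other without, at the place where they differ Compound 4 ends level with the hydroxymethyl sugar of compound 1, a 1.0-fold higher number from compound 1 to compound 4 (0.01 log units; within the scatter). Whether an amine or a methoxy group at this carbon would also follow this reversal stays open, and the compounds shown do not explain the reversal itself.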